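The source may report more compounds than this note shows. Statements on the series, on what has been measured and on what is new or still open speak of the compounds shown alone.

Of the compounds shown here, two sharing one core have been measured in an ADME assay on BHK-21 cells (Mesocricetus auratus) for cytotoxicity, read by MTT assay, with a stated time of 72 h; a higher number here means that more compound is tolerated, a lower number that less compound is tolerated. Compound 1 (`NS(=O)(=O)c1ccc(N2N=C(c3ccc(Oc4ccccc4)cc3)CC2c2cccc(Cl)c2)cc1`) gives 9000 nM, and compound 2 (`NS(=O)(=O)c1ccc(N2N=C(c3ccc(Oc4ccccc4)cc3)CC2c2ccc(F)cc2)cc1`) gives 8000 nM. Going by the values given here, compound 2 therefore stands within the scatter of compound 1, the only other compound measured, and the two cannot be ranked. Compound 3 (`Cc1ccccc1C1CC(c2ccc(Oc3ccccc3)cc2)=NN1c1ccc(S(N)(=O)=O)cc1`) keeps the core of compound 2 and carries 2-methylphenyl in place of 4-fluorophenyl on a saturated ring carbon. Among the compounds with values here, one measured step bears on this change, as it falls at the same place: a 1.1-fold lower number from compound 1 to compound 2 (0.05 log units; within the scatter). That swap of one substituted phenyl group for another left the number within the scatter. Within the data shown here, it is a single step, however, and no measured compound carries 2-methylphenyl, so the data give no direct reading on that group. A step beyond the scatter in this assay is not expected, and no direction can be argued. The expected step is no change at the digits printed from compound 2 to compound 3 (within the scatter). For compound 3 the estimated value is 8000 nM, with an expected range of 4000 nM to 16000 nM.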

Compound 3, half-maximal cytotoxic concentration: 7000 nM
The estimate for compound 3 lay 1.1-fold (0.06 log units) above the measured number, and the stated range covers the measured number.
By their numbers in this assay, from the lowest: compounds 3, 2 and 1 (each within the scatter of the next).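

In this assay the new compound shows a 1.1-fold lower number from compound 2 to compound 3 (0.06 log units; within the scatter) and a 1.3-fold lower number from compound 1 to compound 3 (0.11 log units; within the scatter) and so both steps lie within the scatter, at the same saturated ring carbon as the earlier step. Where the earlier compounds offered a single swap between two halogen-bearing phenyl groups, compound 1, compound 2 and compound 3 now give three substituted phenyl groups on this carbon with no pair separated beyond the scatter. The entering 2-methylphenyl holds carbon only, whereas 4-fluorophenyl holds fluorine and 3-chlorophenyl holds chlorine, and this difference in the group goes with no step beyond the scatter; no measurement that would explain this reading is at hand.

From the compounds shown here alone, all three groups are phenyl rings with one substituent, so it remains open whether the number would hold with an amine or a carboxylic acid on that ring, or with a longer chain in place of the ring. Every step shown falls on this one saturated ring carbon, and the reading at other places on the shared core also remains open.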